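A Methyl Replaces Chlorine on the Phenyl Ring

A few compounds are considered here, and "the series" means these few. Any claim that something is new, unique, unknown or untested is made for them only; others in the source may bear on it.

Three analogues sharing one core have been examined in an ADME assay on HeLa cells (Homo sapiens) for cytotoxicity, read by MTT assay (on this read-out lower numbers stand for higher toxicity in this test and higher numbers for lower toxicity in this test), and all three sit at the same place. Compound 1 `Cc1nc(-c2cccnc2)sc1-c1nnc(-c2ccc(Br)cc2)o1` gives > 100 ug/mL, which is a limit of the assay rather than a number. Compound 2 `Cc1nc(-c2cccnc2)sc1-c1nnc(-c2ccccc2Cl)o1` likewise gives > 100 ug/mL, again only a limit. Compound 3 `Cc1nc(-c2cccnc2)sc1-c1nnc(-c2ccc(Cl)cc2)o1`, carrying a 4-chlorophenyl, gives > 100 ug/mL, also a limit. Because all three values sit at the limit of > 100 ug/mL in this assay, at which 3 of the 3 values shown sit, none of the steps among them can be read: the step that the two limits leave unreadable from compound 1 to compound 2, the step that the two limits leave unreadable from compound 1 to compound 3 and the step that the two limits leave unreadable from compound 2 to compound 3 are each hidden by the two limits.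

Compound 4 `Cc1ccc(-c2nnc(-c3sc(-c4cccnc4)nc3C)o2)cc1` differs from compound 3 by methyl in place of chloro on an aromatic carbon, a methyl in place of a chloro on an aromatic carbon. The measured steps that bear on this change, the swap of chloro for bromo and the move from 2-chlorophenyl to 4-chlorophenyl, were all unreadable, so they give no direction and no size. For the measured compounds named here, since no measured compound reached a readable number, the step that the limit leaves unreadable from compound 3 to compound 4 is expected to stay within the scatter. Compound 4 is therefore estimated at 150 ug/mL in this assay, between 70 ug/mL and 400 ug/mL, and most likely reported again as a limit.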

Compound 4, half-maximal cytotoxic concentration: > 100 ug/mL
Compound 4 was reported as a limit (the forecaster's own chance of this, stated with the estimate: 85%); the middle value is on the limit's open side.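

In this assay compound 4 gives > 100 ug/mL, again a limit. For the compounds shown here, no step from compound 1, compound 2 or compound 3 to compound 4 can be read, and all four compounds stand at one place: the limit of > 100 ug/mL in this assay, at which 4 of the 4 values shown sit. The compounds shown leave open whether chloro, bromo or methyl on the phenyl ring changes the half-maximal cytotoxic concentration at all.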